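This account rests on a few compounds, and the source may have more. Where it says the series, first, only, none or still open, it means among the compounds named here.

Compound 1 `COc1ccccc1N1CCN(CCn2nc(-n3cnc4ccccc43)ccc2=O)CC1` and compound 2 `O=c1ccc(-n2cnc3ccccc32)nn1CCN1CCN(c2ccccc2Cl)CC1` share one core and differ only by chloro in place of methoxy on an aromatic carbon. In an assay on cell membranes from brain for binding affinity to Adrenergic receptor alpha-1 (Rattus norvegicus), read by radioligand binding (a higher number here means a weaker inhibitor, a lower number a stronger inhibitor), compound 1 gives 33 nM, while compound 2 gives 70.4 nM, so that a 2.1-fold higher number from compound 1 to compound 2 (0.33 log units; beyond the scatter). Compound 3 `COc1ccccc1N1CCN(CCCCCCn2nc(-n3ccnc3)ccc2=O)CC1` carries a different core; the difference between the two cores is not broken down here. In this assay compound 3 gives 52.5 nM, a number that sits within the scatter of compound 2 and compound 1 alike. Compound 4 `O=c1ccc(-n2ccnc2)nn1CCCCCCN1CCN(c2ccccc2Cl)CC1` repeats the same change on the core of compound 3: chloro in place of methoxy on an aromatic carbon, at the same kind of place as before. Because a 2.1-fold higher number from compound 1 to compound 2 (0.33 log units; beyond the scatter), a step of similar size is expected here, namely a 2.1-fold higher number from compound 3 to compound 4 (0.32 log units; beyond the scatter). Compound 4 is therefore estimated at 110 nM, with a likely range from 50 nM to 250 nM.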

Compound 4, inhibition constant: 29.7 nM
The estimate for compound 4 lay 3.7-fold (0.57 log units) above the measured number; measured number outside the range, below it.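

In this assay, among the compounds shown here, 2-chlorophenyl in place of 2-methoxyphenyl on the core of compound 3 gives a 1.8-fold lower number from compound 3 to compound 4 (0.25 log units; within the scatter), so on this core the change produces no step that can be told from the scatter. The step therefore did not carry over unchanged from one core to the other: the same change on two cores in this assay, a 2.1-fold higher number (0.33 log units; beyond the scatter) from compound 1 to compound 2 and a 1.8-fold lower number (0.25 log units; within the scatter) from compound 3 to compound 4, 3.8-fold (0.58 log units) apart, beyond the scatter of two such steps. This shows that, in this series, the step on one core cannot be relied on for the other, but two pairs do not show which part of the cores makes the difference or how the change would behave on a further core.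

As far as these compounds go, it remains open which part of the difference between the cores goes with the changed step. Also open, from the compounds shown here alone, is how a fluoro or methyl group at the same place, or a shorter chain on the core of compound 3, would read in this assay.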